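The source may report more compounds than this note shows. Statements on the series, on what has been measured and on what is new or still open speak of the compounds shown alone.

Compound 1 `COc1c(NCCN)c(F)cc2c(=O)c(C(=O)O)cn(Cc3ccc(-c4ccccc4)cc3)c12`: 10%
Compound 2 `NC[C@@H]1CCN(c2cc3c(cc2F)c(=O)c(C(=O)O)cn3Cc2nc(-c3ccncc3)no2)C1`: 10%

In an assay on isolated protein for inhibition of DNA topoisomerase 1 (Homo sapiens), with a stated time of 15 min, tested at 200 uM (a lower number here means less inhibition, a higher number more inhibition at the concentration tested (going by the name of the read-out)), compound 1 gives 10%. Compound 2 gives the same number in this assay, namely 10%, so compound 1 stands level with its nearest neighbour. Compound 3 `COc1c(N2CC[C@@H](CO)C2)c(F)cc2c(=O)c(C(=O)O)cn(Cc3ccc(-c4ccccc4)cc3)c12` has not yet been measured. It differs from compound 1 in one place: 3-(hydroxymethyl)pyrrolidin-1-yl in place of (2-aminoethyl)amino on an aromatic carbon. Among the measured compounds shown here, no step between two measured compounds that differ in one place is available, so the data give no measured size for such a change. Compound 3 is therefore expected to move little, with a step of a number 2 percentage points higher from compound 1 to compound 3 (within the scatter) that stays within the scatter. The estimated value of compound 3 in this assay is 12%, ranging from 0% to 30%.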

Compound 3, a percentage reported as inhibition, at one concentration (the size of the read-out at that concentration, not a potency): 10%
Compound 3: middle estimate off by 2 percentage points, on the high side; measured number inside the range.
By their numbers in this assay, from the lowest: compounds 1, 2 and 3 (each within the scatter of the next).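

In this assay, putting 3-(hydroxymethyl)pyrrolidin-1-yl in place of (2-aminoethyl)amino on this aromatic carbon, ortho to both the fluoro and the methoxy group, gives no change at the digits printed from compound 1 to compound 3 (within the scatter). Among the compounds shown here, this is the first measured size for a change at this position: here, exchanging an open chain for a five-membered non-aromatic ring does not move the read-out beyond the scatter. No available measurement offers a reason for this result. From the compounds shown here alone, whether a piperazine or a carboxylic acid at this carbon would move the number stays open. A reading at one concentration also gives no potency.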